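Fluorine on the Phenyl Ring of Two Guanidine Cores

The compounds below may be only part of what the source reports. "The series", "measured", "known", "first", "only" and "open" are said of these compounds alone.

Compound 1 `N=C(NCCCc1c[nH]cn1)NCCCC(c1ccccc1)c1ccccn1` and compound 2 `N=C(NCCCc1c[nH]cn1)NCCCC(c1ccc(F)cc1)c1ccccn1` share one core and differ only in that (fluoro in place of hydrogen on an aromatic carbon). In a functional assay on cardiac atrium for agonist activity at histamine H2 receptor (Cavia porcellus) (on this read-out higher numbers stand for higher potency (the scale is a negative logarithm) and lower numbers for lower potency), compound 1 gives 6.61, while compound 2 gives 6.87, a step of a number 0.26 log units higher from compound 1 to compound 2 (within the scatter). Compound 3 `N=C(NCCCc1c[nH]cn1)NCCC(c1ccccc1)c1ccccn1` rests on a different core; the difference between the two cores is not broken down here. In this assay compound 3 gives 7.39, the highest of the three numbers and beyond the scatter from both others. Compound 4 `N=C(NCCCc1c[nH]cn1)NCCC(c1ccc(F)cc1)c1ccccn1` differs from compound 3 by the same change, (fluoro in place of hydrogen on an aromatic carbon), at a place described in identical words. Because the measured step was a number 0.26 log units higher from compound 1 to compound 2 (within the scatter), the change to compound 4 is expected to be a number 0.26 log units higher from compound 3 to compound 4 (within the scatter). Compound 4 is therefore estimated at 7.65, likely between 7.2 and 8.1.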

Compound 4, negative logarithm of the half-maximal effective concentration: 8.01
Compound 4: the middle estimate sits 0.36 log units below what was measured, within the range that was stated.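

In this assay the change from phenyl to 4-fluorophenyl gave a number 0.62 log units higher from compound 3 to compound 4 (beyond the scatter). Set beside the earlier step, this one does not differ from it by more than repeated measurements would allow: the same change on two cores in this assay, a number 0.26 log units higher (within the scatter) from compound 1 to compound 2 and a number 0.62 log units higher (beyond the scatter) from compound 3 to compound 4, 0.36 log units apart, within the scatter of two such steps. Within the data shown here, the change therefore carried across these two cores in this assay, but two pairs do not show that the size of the step would hold on any further core, and only the step on the core of compound 3 lies beyond the scatter.

The compounds shown leave open whether chloro or methoxy in place of the fluoro would carry across these cores in the same way. They also leave open how the change behaves on a core with a still longer chain.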